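Series notes: thiophen-2-yl at the aryl position of compound 2

This account rests on a few compounds, and the source may have more. Where it says the series, first, only, none or still open, it means among the compounds named here.

Two compounds of the shared core have numbers. Compound 1 `COc1ccc(-c2cn3ccnc3c(-c3ccc4ncn(C5CCCCC5)c4c3)n2)cc1` carries a 4-methoxyphenyl group on an aromatic carbon; in a functional assay on SK-MEL-5 cells (Homo sapiens) for inhibition, read by sulforhodamine B assay, with a stated time of 48 h, tested at 10 uM (a higher number here means more inhibition at the concentration tested (going by the name of the read-out), a lower number less inhibition), compound 1 gives 92.3%. Compound 2 `Fc1ccccc1-c1cn2ccnc2c(-c2ccc3ncn(C4CCCCC4)c3c2)n1` carries a 2-fluorophenyl group at the same place, and in this assay compound 2 gives 6.5%. For the measured compounds named here, the only step between them, a number 85.8 percentage points lower from compound 1 to compound 2 (beyond the scatter), puts compound 2 at the lowest of the two numbers, with compound 1 far above it.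

Compound 3 `c1csc(-c2cn3ccnc3c(-c3ccc4ncn(C5CCCCC5)c4c3)n2)c1` differs from compound 2 in one place: thiophen-2-yl in place of 2-fluorophenyl on an aromatic carbon. Going by the values given here, no measured step involves thiophen-2-yl, so the step from compound 1 to compound 2 is the only one that bears on this change, and it shows that a single aryl exchange at this carbon can move the read-out by a very large amount in either direction. The expected step is therefore a number 33.5 percentage points higher from compound 2 to compound 3 (beyond the scatter), upward but with wide uncertainty. For compound 3 in this assay the estimate is 40%, with a range from 5% to 85%.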

Compound 3, a percentage reported as inhibition, at one concentration (the size of the read-out at that concentration, not a potency): 8.05%
Compound 3: the middle estimate sits 32 percentage points above what was measured; the measured number falls inside the stated range.
By their numbers in this assay, from the lowest: compounds 2 and 3 (each within the scatter of the next); then compound 1.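

In this assay the exchange gives a number 1.6 percentage points higher from compound 2 to compound 3 (within the scatter) at this carbon, so 2-fluorophenyl and thiophen-2-yl cannot be told apart here, even though the ring size and the hetero atom both change. The other step, a number 84.3 percentage points lower from compound 1 to compound 3 (beyond the scatter) for the exchange from 4-methoxyphenyl, shows that the large gap first seen with 2-fluorophenyl is not peculiar to that group, and among the three aryl groups shown only 4-methoxyphenyl goes with a high number. No evidence on hand bears on what separates 4-methoxyphenyl from the other two groups.

Left open is whether 4-ethoxyphenyl, 4-hydroxyphenyl or 4-aminophenyl at this carbon would keep the high number of compound 1. Also open, on these data alone, is whether unsubstituted phenyl would sit with compound 1 or with compound 2 and compound 3.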